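This account rests on a few compounds, and the source may have more. Where it says the series, first, only, none or still open, it means among the compounds named here.

Measured so far:
compound 1 `COc1ccccc1N1C(=O)CSC1C(=O)NCCCCc1ccccc1`: 0%
compound 2 `O=C(NCCCCc1ccccc1)c1cccc(C2SCC(=O)N2c2ccccc2)c1`: 96%

In a functional assay on HOS-TE85 cells (Homo sapiens) for inhibition, read by CCK-8 assay, with a stated time of 72 h, tested at 1 uM (a higher number here means more inhibition at the concentration tested (going by the name of the read-out), a lower number less inhibition), compound 1 gives 0%, while compound 2 gives 96%. Compound 2 thus stands highest of the two numbers, and its gap to compound 1 lies beyond the scatter. Compound 3 `O=C(NCCCCc1ccccc1)c1cccc(C2SCC(=O)N2c2cccc(F)c2)c1` is not yet measured. It differs from compound 2 by fluoro in place of hydrogen on an aromatic carbon, which reads, cut one bond further out, as phenyl to 3-fluorophenyl. Among the measured compounds shown here, since no measured pair shows this change, the step is expected to be small, likely none beyond the scatter, and compound 3 is expected near 90%, within 70% to 99%, a step of a number 6 percentage points lower from compound 2 to compound 3 (within the scatter).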

Compound 3, a percentage reported as inhibition, at one concentration (the size of the read-out at that concentration, not a potency): 94%
The estimate for compound 3 lay 4 percentage points below the measured number; the range from low to high includes it.
By their numbers in this assay, from the lowest: compound 1; then compounds 3 and 2 (each within the scatter of the next).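

In this assay, the change from phenyl to 3-fluorophenyl gives a number 2 percentage points lower from compound 2 to compound 3 (within the scatter), so this position carries fluoro with no step beyond the scatter. Among the compounds shown here, this is the first change confined to one place, as compound 1 and compound 2 differ in more than one. Nothing measured here bears on the reason for this result.

Open, as far as these compounds go, is whether an amine or a carboxylic acid at this position gives a similar number, and whether fluoro on another ring carbon does. A single concentration leaves any potency difference between compound 2 and compound 3 unread.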